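Tricyclic hydrocarbon series: bromide to carboxylic acid

The compounds below may be only part of what the source reports. "The series", "measured", "known", "first", "only" and "open" are said of these compounds alone.

Measured so far:
compound 1 `BrC12CCCC3CC(CCC31)C2`: no result reported
compound 2 `C1=C2CCCC3CC1CCC23`: no result reported
compound 3 `O[C@H]1C2CCCC3C[C@H]1CC[C@H]32`: 1800000 nM

In an ADME assay (Gallus gallus) for cytotoxicity, read by microscopy, with a stated time of 24 h (on this read-out higher numbers stand for lower toxicity in this test and lower numbers for higher toxicity in this test), compound 3 gives 1800000 nM as its minimum cytotoxic concentration. Among the compounds with values here, compound 1 stands at no result reported on this read-out, and compound 2 is a further entry in the same position with no result reported, so the only number for the shared core comes from compound 3.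

The step under consideration leads from compound 1 to compound 4 `O=C(O)C12CCCC3CC(CCC31)C2`. The change is carboxy in place of bromo on a saturated ring carbon. Within the data shown here, no step between measured compounds exists for this pair, so no direction can be read from the numbers; the expectation is that compound 4 lands near compound 3 on this assay, with any step from compound 1 not beyond the scatter in this assay.

Compound 4 is expected to give about 1500000 nM, within 400000 nM to 5000000 nM, in this assay.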

Compound 4, minimum cytotoxic concentration: 10000000 nM
For compound 4 the middle estimate is 6.7-fold (0.82 log units) below the measured one; measured number above the stated range.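

Within the data shown here, compound 1 and compound 4 yield no new step that can be read in this assay for this series. The compounds shown leave open how carboxy in place of bromo on the shared core bears on the minimum cytotoxic concentration. No supporting data bear on the result of compound 4.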